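Compound 4: a chlorinated, hydroxylated phenyl replaces the bare phenyl

The source may report more compounds than this note shows. Statements on the series, on what has been measured and on what is new or still open speak of the compounds shown alone.

Compound 3 `COc1ccc(C(=O)/C=C/c2ccccc2)c2c1C=CC(C)(C)O2` carries a plain phenyl on its chain. In a functional assay on HCT-116 cells (Homo sapiens) for antiproliferative activity, read by MTT assay, with a stated time of 24 h (on this read-out lower numbers stand for stronger inhibition and higher numbers for weaker inhibition), compound 3 gives > 10000 nM, which is a limit of the assay and not a number. Compound 1 `COc1ccc(C(=O)/C=C/c2ccc(-c3ccccc3)cc2)c2c1C=CC(C)(C)O2` likewise reaches only a limit, > 10000 nM in this assay. For the measured compounds named here, compound 2 `CCN(CC)c1ccc(/C=C/C(=O)c2ccc(OC)c3c2OC(C)(C)C=C3)cc1` is the one compound with a number, 620 nM in this assay, and the step of an at least 16-fold higher number from compound 2 to compound 3 (1.20 log units; beyond the scatter) shows how much the diethylamino on the aromatic carbon is worth. The step that the two limits leave unreadable from compound 1 to compound 3 cannot be read, since both ends are limits (the limit of > 10000 nM in this assay, at which 2 of the 3 values shown sit).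

Compound 4 `COc1ccc(C(=O)/C=C/c2cc(Cl)ccc2O)c2c1C=CC(C)(C)O2` differs from compound 3 by 5-chloro-2-hydroxyphenyl in place of phenyl on a double-bonded chain carbon bound to a double-bonded chain carbon. Going by the values given here, none of the measured steps involves a hydroxyl or a chlorine; the only large step rests on a diethylamino, a different group. Among the compounds with values here, no step therefore bears directly on this change, and the author expects nothing beyond the scatter, with compound 4 most likely remaining at the limit. Compound 4 is estimated at 9000 nM, between 2500 nM and 30000 nM, which would mean an expected step of an at least 1.1-fold lower number from compound 3 to compound 4 (0.04 log units; that floor lies within the scatter).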

Compound 4, half-maximal inhibitory concentration: 5240 nM
Compound 4: middle estimate off by 1.7-fold (0.23 log units), on the high side, within the range that was stated.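

At this position, on a double-bonded chain carbon bound to a double-bonded chain carbon, a substituted phenyl without a diethylamino group now gives a readable number: in this assay compound 4 gives 5240 nM. Against the plain phenyl, the change reads as an at least 1.9-fold lower number from compound 3 to compound 4 (0.28 log units; that floor lies within the scatter), so no gain beyond the scatter can be claimed, even though compound 4 no longer sits at the limit: the limit of > 10000 nM in this assay, at which 2 of the 4 values shown sit. The number of compound 4 also stays higher than that of compound 2, which gives 620 nM in this assay.

The compounds shown leave open whether the chlorine, the hydroxyl or the two together account for the number of compound 4. They also leave open how a smaller amine such as dimethylamino, or a carboxylic acid, would read on this phenyl.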